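A few compounds are considered here, and "the series" means these few. Any claim that something is new, unique, unknown or untested is made for them only; others in the source may bear on it.

Of the compounds shown here, two with the same core have been measured in an ADME assay on microsomes from liver (Homo sapiens) for metabolic stability, read by LC-MS, tested at 1 mM; on this read-out lower numbers stand for a shorter-lived compound and higher numbers for a longer-lived compound. Compound 1 `N#Cc1ccc(F)cc1Cn1c(N2CCC[C@@H](N)C2)nc2c(-c3cccs3)c[nH]c2c1=O`, which carries a thiophen-2-yl group, gives 0.585 h. Compound 2 `CS(=O)(=O)c1ccc(-c2c[nH]c3c(=O)n(Cc4cc(F)ccc4C#N)c(N4CCC[C@@H](N)C4)nc23)c(F)c1`, which carries a 2-fluoro-4-(methylsulfonyl)phenyl group in its place, gives > 3.33 h, and this is a limit of the assay, not a number.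

Compound 3 `CS(=O)(=O)c1ccc(-c2c[nH]c3c(=O)n(Cc4cc(F)ccc4C#N)c(N4CCC[C@@H](N)C4)nc23)cc1F` differs from compound 2 in one place: 3-fluoro-4-(methylsulfonyl)phenyl in place of 2-fluoro-4-(methylsulfonyl)phenyl on an aromatic carbon. A 3-fluoro-4-(methylsulfonyl)phenyl group takes the place of the 2-fluoro-4-(methylsulfonyl)phenyl group, and the two compounds have the same atoms, joined differently.

Within the data shown here, only one measured step bears on this, an at least 5.6-fold higher number from compound 1 to compound 2 (0.75 log units; beyond the scatter), and it lies beyond the scatter. Among the measured compounds shown here, it exchanges one group for a very different one, whereas no measured step tests a change like this one. Compound 3 keeps the same atoms as the group that entered in an at least 5.6-fold higher number from compound 1 to compound 2 (0.75 log units; beyond the scatter), so no step beyond the scatter is expected in this assay. The estimated size of a number no higher from compound 2 to compound 3 (the limit leaves the size open) is therefore small, and the assay may again report only a limit. For compound 3 the expected half-life is 3.3 h, with an estimated range of 1.7 h to 6.5 h.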

Compound 3, half-life: > 3.33 h
Compound 3: only a limit was reported (the forecaster's own chance of this, stated with the estimate: 55%); at least 1.0-fold (0.00 log units) between middle value and limit.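

In this assay compound 3 gives > 3.33 h, which is a limit of the assay and not a number. Placing the 3-fluoro-4-(methylsulfonyl)phenyl group on the shared core instead of thiophen-2-yl gives an at least 5.6-fold higher number from compound 1 to compound 3 (0.75 log units; beyond the scatter), so at this position on the five-membered aromatic ring, the long half-life is not confined to the 2-fluoro-4-(methylsulfonyl)phenyl group and also appears when the same atoms are joined differently. The step from compound 2 to compound 3 cannot be read, because both compounds give only a limit, and the two groups therefore cannot be ranked: the limit of > 3.33 h in this assay, at which 2 of the 3 values shown sit.

The values shown leave open how far the half-lives of compound 2 and compound 3 extend and whether one of these two groups outlasts the other, which only a measurement able to go past this limit could settle. They also do not separate the contribution of the fluorine from that of the methylsulfonyl group, a question that a compound carrying a plain 4-(methylsulfonyl)phenyl group or an unsubstituted phenyl ring at this position could help to answer.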